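This account rests on a few compounds, and the source may have more. Where it says the series, first, only, none or still open, it means among the compounds named here.

Compound 1 `Cc1ccccc1Cn1cc(COc2ccc3c(=O)ccoc3c2)nn1`: in a functional assay on MDA-MB-231 cells (Homo sapiens) for cytotoxicity, read by MTT assay, with a stated time of 48 h (on this read-out higher numbers stand for weaker inhibition and lower numbers for stronger inhibition), compound 1 gives > 100000 nM, which is a limit of the assay and not a number.
Compound 2 `O=c1ccoc2cc(OCc3cn(Cc4cccc(Cl)c4)nn3)ccc12`: compound 2 gives > 100000 nM, again a limit of the assay.
Compound 3 `O=c1ccoc2cc(OCc3cn(Cc4ccccc4Cl)nn3)ccc12`: compound 3 gives 15100 nM.

Compound 1 therefore stands at the edge of what the assay can report, at the limit of > 100000 nM in this assay, at which 2 of the 3 values shown sit, and only compound 3 gives a measured number. The compound to be measured next is compound 4 `COc1ccc(Cn2cc(COc3ccc4c(=O)ccoc4c3)nn2)cc1`, which differs from compound 1 by 4-methoxyphenyl in place of 2-methylphenyl on a saturated chain carbon bound to an aromatic nitrogen.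

For the measured compounds named here, no measured step makes this exact change. The nearest are the steps that swap the group on the same saturated chain carbon: the step that the two limits leave unreadable from compound 1 to compound 2 is unreadable because both ends sit at a limit, while the step of an at least 6.6-fold lower number from compound 2 to compound 3 (0.82 log units; beyond the scatter) and the step of an at least 6.6-fold lower number from compound 1 to compound 3 (0.82 log units; beyond the scatter) both show that only the 2-chlorophenyl of compound 3 gives a value inside the assay's range. Two of the three groups tried on this carbon leave the number at the limit, and the 4-methoxyphenyl of compound 4 resembles neither of them closely.

The expectation for compound 4 is therefore no step beyond the scatter, a number no higher from compound 1 to compound 4 (the limit leaves the size open), with a value most likely again reported only as a limit. The estimate for compound 4 is 100000 nM, in a range from 30000 nM to 300000 nM.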

Compound 4, half-maximal inhibitory concentration: > 100000 nM
Compound 4: a limit, no number; the forecaster's own chance of this, stated with the estimate: 70%; the middle value lies on the limit itself.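

In this assay, the 4-methoxyphenyl group of compound 4 brings no measured number and adds a third compound at the edge of what the read-out can report: the limit of > 100000 nM in this assay, at which 3 of the 4 values shown sit.

Set against the 2-chlorophenyl group, the change gives an at least 6.6-fold higher number from compound 3 to compound 4 (0.82 log units; beyond the scatter). On the saturated chain carbon bound to an aromatic nitrogen, compound 3 therefore remains the only one of the four that gives a number, while compound 1, compound 2 and now compound 4 do not, even with a hydrogen-bond acceptor present in the entering group. The steps that link compound 4 to compound 1 and to compound 2 cannot be read, as both ends of each are limits.

From the compounds shown here alone, how far compound 1, compound 2 and compound 4 lie beyond the limit, and whether they differ from one another at all, stays open. Also open, going by these compounds, is whether the number of compound 3 depends on its chloro group in particular, which a fluoro or bromo group in its place, or a cyclohexyl group in place of the whole 2-chlorophenyl, would help to settle.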